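Swapping cyclopropylmethyl for 2-fluorophenyl on compound 1

This account rests on a few compounds, and the source may have more. Where it says the series, first, only, none or still open, it means among the compounds named here.

The values measured in an ADME assay on liver for metabolic stability, with Liver microsome (Homo sapiens) as the target, read by LC-MS, using microsomes (a lower number here means slower removal, a higher number faster removal of the compound), are as follows
Compound 1 `O=C(NCc1cc(Cl)ccc1-n1cnnn1)[C@@H]1C[C@@H]2C[C@@H]2N1C(=O)[C@H](O)CC1CC1` gives < 12 mL.min-1.g-1 (a limit)
Compound 2 `O=C(NCc1cc(Cl)ccc1-n1cnnn1)[C@@H]1C[C@H]2C[C@H]2N1C(=O)[C@H](O)CC1CC1` gives 25 mL.min-1.g-1
Compound 3 `CCCC[C@@H](O)C(=O)N1C[C@H]2C[C@H]2[C@H]1C(=O)NCc1cc(Cl)ccc1-n1cnnn1` gives 32 mL.min-1.g-1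

Compound 1 stands at the limit of < 12 mL.min-1.g-1 in this assay, at which 1 of the 3 values shown sits, and that reading is a limit and not a number. Compound 4 `O=C(NCc1cc(Cl)ccc1-n1cnnn1)[C@@H]1C[C@@H]2C[C@@H]2N1C(=O)[C@H](O)c1ccccc1F` keeps the core of compound 1 and carries 2-fluorophenyl in place of cyclopropylmethyl on a saturated chain carbon bound to a carbonyl carbon and an oxygen on a saturated carbon.

For the measured compounds named here, no measured step exchanges this group. Going by the values given here, the only step available is an at least 2.0-fold higher number from compound 1 to compound 2 (0.31 log units; beyond the scatter) and it comes with the fact that compounds 1 and 2 differ only in the configuration as drawn so it leaves the group untouched. That step bears on the change only indirectly, as a gauge of how far numbers can move among these close relatives in this assay for a single alteration.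

The starting point therefore remains the limit of compound 1 at < 12 mL.min-1.g-1 as the only anchor. A small upward step, no larger than that gauge, is expected, and it is estimated as an at least 1.1-fold higher number from compound 1 to compound 4 (0.06 log units; that floor lies within the scatter) in this read-out. Compound 4 is expected at 14 mL.min-1.g-1 with an estimated range of 6 mL.min-1.g-1 to 32 mL.min-1.g-1 in this assay once it is measured.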

Compound 4, intrinsic clearance in microsomes: < 12 mL.min-1.g-1
Compound 4 ended at the assay's limit; the forecaster's own chance of this, stated with the estimate: 35%; middle value at least 1.1-fold (0.06 log units) from the limit.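

Compound 1 and compound 4 give no readable step, because both readings are a limit and not a number, and the two stand at the same one: the limit of < 12 mL.min-1.g-1 in this assay, at which 2 of the 4 values shown sit.

The compounds shown leave open whether 2-fluorophenyl in place of cyclopropylmethyl changes the intrinsic clearance in microsomes at all and, if it does, in which direction and how far.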